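Loss of an Ester Group on a Shared Thiol-Substituted Core

This account rests on a few compounds, and the source may have more. Where it says the series, first, only, none or still open, it means among the compounds named here.

Compound 1 `Cc1oc(=O)oc1COC(=O)C1=C(S[C@@H]2CN[C@H](C(=O)Nc3cccc(C(=O)OCc4oc(=O)oc4C)c3)C2)[C@H](C)[C@@H]2[C@@H]([C@@H](C)O)C(=O)N12` was examined in an ADME assay on a cell-free system (plasma, Rattus norvegicus) for metabolic stability, read by LC-MS, with a stated time of 60 min, at 37 degrees C, tested at 50 uM (on this read-out lower numbers stand for a less stable compound and higher numbers for a more stable compound), where compound 1 gives 0%. Two further compounds were run in the same test. Compound 2 `C[C@@H](O)[C@H]1C(=O)N2C3=C(S[C@@H]4CN[C@@H](C4)C(=O)Nc4cccc(c4)C(=O)OCCCOC3=O)[C@H](C)[C@H]12` gives 0%, and compound 3 `CCOC(=O)C1=C(S[C@H]2C[C@@H](C(=O)Nc3cccc(C(=O)OCC)c3)N(Cc3oc(=O)oc3C)C2)[C@H](C)[C@@H]2[C@@H]([C@@H](C)O)C(=O)N12` gives 0%. Compound 1 stands level with compound 2 and compound 3 at the digits shown; its nearest neighbour is compound 2 and its furthest is compound 3, and in both cases the gap lies within the scatter. Among the compounds with values here, no single-point step between measured compounds is available.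

Compound 4 `Cc1oc(=O)oc1COC(=O)c1cccc(NC(=O)[C@@H]2C[C@H](SC3=C(C(=O)O)N4C(=O)[C@H]([C@@H](C)O)[C@H]4[C@H]3C)CN2)c1` has not yet been measured. It differs from compound 1 as follows: a hydrogen atom in place of a group of 8 heavy atoms (5 carbon, 3 oxygen; one five-membered aromatic ring with 2 hetero atoms), on an oxygen next to a carbonyl group.

Within the data shown here, since all three measured compounds sit at the floor of the read-out, the data give no measured step on which to rest a direction. The change is nonetheless a large one, and compound 4 is expected to move upward in this assay by a number 75 percentage points higher from compound 1 to compound 4 (beyond the scatter). For compound 4 the estimate in this assay is 75%, with a range from 30% to 100%.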

Compound 4, percent of the compound remaining in the plasma assay: 0%
Compound 4: the middle estimate sits 75 percentage points above what was measured, and the stated range ends above it.
By their numbers in the plasma assay, from the lowest: compounds 1, 2, 3 and 4 (each within the scatter of the next).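

In the plasma assay, a hydrogen atom in place of the group of 8 heavy atoms, on an oxygen next to a carbonyl group, gives no change at the digits printed from compound 1 to compound 4 (within the scatter), so the read-out stays at its floor even with this group gone from the position. In a physicochemical assay for metabolic stability, read by LC-MS, in phosphate buffer, with a stated time of 3 h, at pH 7.4, tested at 50 uM (on this read-out higher numbers stand for a more stable compound and lower numbers for a less stable compound), compound 1 gives > 95%, which is a limit of the assay. In the physicochemical assay compound 4 gives > 95%, again a limit of the assay, so the step for this change cannot be read: the limit of > 95% in the physicochemical assay, at which 2 of the 2 values shown sit.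

Going by these compounds, it remains open whether a carboxylic acid in place of the other ester group, which compound 4 still carries, would lift the value in the plasma assay. With all four compounds at the floor of that read-out, any difference between them also remains hidden.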